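This account rests on a few compounds, and the source may have more. Where it says the series, first, only, none or still open, it means among the compounds named here.

Compounds measured so far
compound 1 `COc1cc(OC)cc(-c2cccc(NC(=O)CCc3ccc4c(c3)B(O)OC4)c2)c1` in an ADME assay on WI-38 cells (Homo sapiens) for cytotoxicity, read by MTT assay, with a stated time of 72 h (a lower number here means a stronger inhibitor, a higher number a weaker inhibitor), gives > 100000 nM as a limit
compound 2 `CC(=O)c1ccc(-c2cccc(NC(=O)CCc3ccc4c(c3)B(O)OC4)c2)cc1` in this assay gives > 100000 nM as a limit

Compound 2 has only a limit in this assay and shares it with compound 1, so the limit of > 100000 nM in this assay, at which 2 of the 2 values shown sit, is all the evidence on where it stands. Going by the values given here, the only measured step is a step that the two limits leave unreadable from compound 1 to compound 2 and it lies on an aromatic carbon, so it gives no size to carry over. Compound 3 `CC(=O)c1ccc(-c2cccc(NC(=O)CCc3cccc4c3C(O)OC4)c2)cc1` carries a group of 10 heavy atoms (8 carbon, 2 oxygen; one five-membered non-aromatic ring with 1 hetero atom, one six-membered aromatic ring of carbon only) in place of a group of 10 heavy atoms (7 carbon, 1 boron, 2 oxygen; one five-membered non-aromatic ring with 2 hetero atoms, one six-membered aromatic ring of carbon only), on a saturated chain carbon, two bonds along the chain from a carbonyl carbon with the change on a saturated chain carbon, two bonds along the chain from a carbonyl carbon. Among the compounds with values here, no measured step covers this replacement, so no step beyond the scatter is expected in this assay and no direction can be given. The expected step that the limit leaves unreadable from compound 2 to compound 3 is an estimate resting on the limit of compound 2 alone. Compound 3 is expected at 120000 nM with an estimated range of 50000 nM to 300000 nM and may well report only a limit again.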

Compound 3, half-maximal inhibitory concentration: > 100000 nM
Compound 3 was reported as a limit; the forecaster's own chance of this, stated with the estimate: 80%; the middle value lies beyond the limit too.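

In this assay compound 3 reports only a limit, as compound 2 does, so no step can be read between compound 2 and compound 3. The compounds shown leave open whether any replacement in this series gives a measurable value in this assay.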